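The source may report more compounds than this note shows. Statements on the series, on what has been measured and on what is new or still open speak of the compounds shown alone.

Measured so far in a physicochemical assay for lipophilicity, at pH 7.4; a lower number here means a more polar compound, a higher number a more lipophilic compound:
- Compound 1 `CNC(=O)c1cc(C(=O)N[C@H]2[C@@H]3COC[C@@H]32)cc2c1OC[C@H]2c1cccnc1`: 1.4
- Compound 2 `CNC(=O)c1cc(C(=O)NC2CC2)cc2c1OC[C@H]2c1ccc(F)cc1`: 3.8

Of these two, compound 1 has the lower number, and compound 2 at 3.8 sits well above it, a gap beyond the scatter of the measurement. Compound 1 therefore stands at the more polar end of what has been seen so far in this assay.

Compound 3 `CNC(=O)c1cc(C(=O)N[C@H]2[C@@H]3COC[C@@H]32)cc2c1OC[C@H]2c1ccccc1C` has not yet been measured. It keeps the core of compound 1 and carries 2-methylphenyl in place of pyridin-3-yl on a saturated ring carbon. The ring nitrogen leaves, and the entering ring is of carbon only.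

Among the measured compounds shown here, no two measured compounds differ in one place only, so no measured step can guide the size of this change. The expectation rests on the structural change alone, starting from compound 1 at 1.4. The estimated step is a number 1.50 log units higher from compound 1 to compound 3 (beyond the scatter), expected to be upward and beyond the scatter. For compound 3 the expected value is 2.9, with an estimated range from 2.3 to 3.5.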

Compound 3, distribution coefficient: 4
Estimate against measurement, compound 3: 1.10 log units below; the whole stated range lies below it.
By their numbers in this assay, from the lowest: compound 1; then compounds 2 and 3 (each within the scatter of the next).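

In this assay, the swap of pyridin-3-yl for 2-methylphenyl on a saturated ring carbon gives a number 2.60 log units higher from compound 1 to compound 3 (beyond the scatter), with the rest of the core of compound 1 left unchanged. Among the compounds shown here, this is the first comparison in which only one place differs, and it shows that this carbon, two ring bonds from the ring oxygen, is a position where the choice of aromatic ring alone can shift the number by a large amount. The swap makes two changes at once, as the ring nitrogen leaves and a methyl group enters, so the step cannot be divided between them, and no measurement shown here explains its size.

A plain phenyl ring on the same carbon would separate the two changes, as it has no ring nitrogen and no methyl group, while a methylpyridine would keep the ring nitrogen and add the methyl group. For the compounds shown here, how the number responds at this position to an amine or a carboxylic acid on the aromatic ring also remains open, as the single step here gives no guide to groups of those kinds.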